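Replacing pyridin-4-yl with phenyl on a shared core

The source may hold more compounds than are shown below. What is called first, only, known or untested is meant among the compounds shown, and "the series" means these compounds.

compound 1 `COc1ccc(S(=O)(=O)N2CCc3cccc(-c4ccc(F)nc4)c32)cc1`: 145 nM
compound 2 `COc1ccc(S(=O)(=O)N2CCc3cccc(-c4ccco4)c32)cc1`: 42 nM
compound 3 `COc1ccc(S(=O)(=O)N2CCc3cccc(-c4ccncc4)c32)cc1`: 69.5 nM

All three values come from a functional assay on MKN-45 cells (Homo sapiens) for inhibition, with a stated time of 72 h; a lower number here means a stronger inhibitor, a higher number a weaker inhibitor. Compound 3 stands with compound 2 at the low end of this small set, the gap between them being a 1.7-fold higher number from compound 2 to compound 3 (0.22 log units; within the scatter). The gap to the remaining compound is clearer, at a 2.1-fold lower number from compound 1 to compound 3 (0.32 log units; beyond the scatter).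

The next structure is compound 4 `COc1ccc(S(=O)(=O)N2CCc3cccc(-c4ccccc4)c32)cc1`, which has phenyl in place of pyridin-4-yl on an aromatic carbon. Among the compounds with values here, no measured pair shows this exact swap, so the evidence is indirect. The three measured compounds differ only in the group at this same place, and those changes have been modest. The largest is a 3.5-fold lower number from compound 1 to compound 2 (0.54 log units; beyond the scatter). With so few groups compared, the data give no direction for a change to phenyl. A step within the scatter is therefore expected in this assay, with no firm direction, although a modest move either way remains possible. The estimate corresponds to an expected 1.2-fold lower number from compound 3 to compound 4 (0.06 log units; within the scatter). Compound 4 is estimated at 60 nM, with an expected range from 25 nM to 150 nM.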

Compound 4, half-maximal inhibitory concentration: 117 nM
Beside the measured number, compound 4's estimate is 2.0-fold (0.29 log units) below it; measured number inside the range.
By their numbers in this assay, from the lowest: compounds 2, 3, 4 and 1 (each within the scatter of the next, the first and the last beyond it).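

Swapping pyridin-4-yl for phenyl removes the ring nitrogen, the hydrogen-bond acceptor counted on that group, and gives a 1.7-fold higher number from compound 3 to compound 4 (0.23 log units; within the scatter) in this assay, so this nitrogen is not needed at this position for a result in the same range. Against the other two groups the picture divides: replacing furan-2-yl with phenyl gives a 2.8-fold higher number from compound 2 to compound 4 (0.44 log units; beyond the scatter), a real loss, whereas replacing 6-fluoropyridin-3-yl with phenyl gives a 1.2-fold lower number from compound 1 to compound 4 (0.09 log units; within the scatter), which cannot be told apart from no change, so only furan-2-yl stands clearly apart from phenyl here. No supporting measurement is available to explain why these groups differ.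

The compounds shown leave open how this position would respond to a group of a different kind, such as an amine, a carboxylic acid or a longer chain in place of an aromatic ring. They also leave open whether a substituent on the phenyl ring of compound 4, such as a methoxy group, would shift the number in either direction.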